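Chloro for trifluoromethyl on the shared core: compound 3

This account rests on a few compounds, and the source may have more. Where it says the series, first, only, none or still open, it means among the compounds named here.

Measured so far:
compound 1, `FC(F)(F)c1ccc(CSc2nc(Nc3ccccc3)c3ccccc3n2)cc1`, a functional assay on PC-3 cells (Homo sapiens) for cytotoxicity, read by MTT assay, with a stated time of 72 h; a higher number here means a weaker inhibitor, a lower number a stronger inhibitor: 20000 nM
compound 2, `FC(F)(F)c1ccc(CSc2nc(Nc3ccccc3C(F)(F)F)c3ccccc3n2)cc1`, this assay: 34800 nM

On the numbers shown, compound 2 sits at the upper end, with compound 1 as its only neighbour; the step of a 1.7-fold higher number from compound 1 to compound 2 (0.24 log units; within the scatter) lies within the scatter, so the two numbers are not separable. Compound 3 `FC(F)(F)c1ccc(CSc2nc(Nc3ccccc3Cl)c3ccccc3n2)cc1` differs from compound 2 by chloro in place of trifluoromethyl on an aromatic carbon. Within the data shown here, the only measured step that touches this position is the one from compound 1 to compound 2, a 1.7-fold higher number from compound 1 to compound 2 (0.24 log units; within the scatter), and it did not leave the scatter: putting trifluoromethyl where hydrogen stood changed nothing of note in this assay. Taking chloro as sitting somewhere between those two cases, the step of a 1.2-fold lower number from compound 2 to compound 3 (0.09 log units; within the scatter) is expected to stay within the scatter as well. For compound 3 the estimate in this assay is therefore 28000 nM, with a range from 12000 nM to 65000 nM.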

Compound 3, half-maximal inhibitory concentration: 20400 nM
Compound 3: middle estimate off by 1.4-fold (0.14 log units), on the high side; the range from low to high includes it.
By their numbers in this assay, from the lowest: compounds 1, 3 and 2 (each within the scatter of the next).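

In this assay, chloro in place of trifluoromethyl, on an aromatic carbon ortho to a large group, gives a 1.7-fold lower number from compound 2 to compound 3 (0.23 log units; within the scatter), and chloro in place of hydrogen gives a 1.0-fold higher number from compound 1 to compound 3 (0.01 log units; within the scatter). Where the earlier pair offered a single replacement, this place now has three substituents, and every step among them lies within the scatter, even with 4 heavy atoms leaving and 1 entering, so hydrogen, chloro and trifluoromethyl cannot be put in any order here. Nothing at hand bears on why these three compounds cannot be told apart.

Open, as far as these compounds go, is whether a group of another kind at this place, such as an amine or a carboxylic acid, would give a step beyond the scatter. Also open, from the compounds shown here alone, is whether a change elsewhere on the shared core would do so.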